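This account rests on a few compounds, and the source may have more. Where it says the series, first, only, none or still open, it means among the compounds named here.

Series notes, histamine receptor set.

Compound 1 `CC(=O)c1ccc(OCCCN2CC[C@H](NC(=O)c3ccc(C#N)cc3)C2)cc1`: 6100 nM in an assay on isolated protein for binding affinity to histamine H2 receptor (Homo sapiens); on this read-out lower numbers stand for stronger inhibition and higher numbers for weaker inhibition.
Compound 2 `O=C(c1ccc(OCCCN2CC[C@H](NS(=O)(=O)c3cccc(F)c3)C2)cc1)C1CC1`: 1600 nM.
Compound 3 `CC(=O)c1ccc(OCCCN2CC[C@H](NC(=O)[C@@H](N)CO)C2)cc1`: 22000 nM.

Compound 2 holds the lowest number of the three; compound 1 sits nearest above it and compound 3 furthest. Going by the values given here, the one measured step within the set, a 3.6-fold higher number from compound 1 to compound 3 (0.56 log units; beyond the scatter), concerns the amide side of the shared core and gives no guide to a change on the sulfonamide. Compound 4 `O=C(c1ccc(OCCCN2CC[C@H](NS(=O)(=O)c3ccccc3F)C2)cc1)C1CC1` differs from compound 2 only in how the same atoms are joined: 2-fluorophenyl in place of 3-fluorophenyl on a sulfonyl sulfur. Among the compounds with values here, no measured pair tests a shift of the fluorine around that ring, so no step beyond the scatter is expected in this assay in either direction. The expected step of a 1.1-fold higher number from compound 2 to compound 4 (0.05 log units; within the scatter) is accordingly small, and compound 4 is estimated at 1800 nM with a range of 600 nM to 5500 nM.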

Compound 4, inhibition constant: 1550 nM
Compound 4: middle estimate off by 1.2-fold (0.06 log units), on the high side; measured number inside the range.
By their numbers in this assay, from the lowest: compounds 4 and 2 (each within the scatter of the next); then compound 1; then compound 3.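

In this assay, 2-fluorophenyl in place of 3-fluorophenyl on a sulfonyl sulfur gives a 1.0-fold lower number from compound 2 to compound 4 (0.01 log units; within the scatter), so these two fluorophenyl groups cannot be told apart on this read-out. Going by these compounds alone, this pair is the only measured comparison on the sulfonyl sulfur, as the earlier step concerned the amide side of the shared core. No evidence bears on this result.

Still open, going by these compounds, is whether a plain phenyl, a chlorophenyl or a methoxyphenyl group on the sulfonyl sulfur would stay within the scatter of compound 2. The compounds shown also leave open how an amine or a carboxylic acid on that ring would read.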